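This account rests on a few compounds, and the source may have more. Where it says the series, first, only, none or still open, it means among the compounds named here.

Measured so far in an assay on SW1353 cells (Homo sapiens) for inhibition, read by a luciferase reporter, with stated times of 30 min and 8 h; a higher number here means a weaker inhibitor, a lower number a stronger inhibitor:
- compound 1 `O=c1sc2ccccc2n1CCCCCCN1CCN(CCCCCCn2c(=O)sc3ccccc32)CC1`: 410 nM
- compound 2 `O=c1oc2ccccc2n1CCCCCN1CCN(CCn2c(=O)oc3ccccc32)CC1`: 4780 nM

Compound 2 at 4780 nM has the higher of the two numbers, which makes it the weaker inhibitor, and its gap to compound 1 lies beyond the usual scatter of repeat measurements. The next compound, compound 3 `O=c1oc2ccccc2n1CCCCCCN1CCN(CCn2c(=O)oc3ccccc32)CC1`, differs from compound 2 in one place: a group of 11 heavy atoms (8 carbon, 1 nitrogen, 2 oxygen; one five-membered aromatic ring with 2 hetero atoms, one six-membered aromatic ring of carbon only) in place of a group of 10 heavy atoms (7 carbon, 1 nitrogen, 2 oxygen; one five-membered aromatic ring with 2 hetero atoms, one six-membered aromatic ring of carbon only), on a saturated chain carbon, five bonds along the chain from an amine nitrogen in a ring on a saturated chain carbon, five bonds along the chain from an amine nitrogen in a ring. Among the measured compounds shown here, no measured pair shows this change alone. Compound 1 at 410 nM differs from compound 2 in more than one place, so it offers only a weak hint toward a lower number. A small move toward a stronger inhibitor is expected, with a 1.6-fold lower number from compound 2 to compound 3 (0.20 log units; within the scatter) estimated to stay within the scatter in this assay for this change. For compound 3 the estimate is 3000 nM with a range from 900 nM to 9000 nM expected.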

Compound 3, half-maximal inhibitory concentration: 3070 nM
Beside the measured number, compound 3's estimate is 1.0-fold (0.01 log units) below it; the measured number falls inside the stated range.
By their numbers in this assay, from the lowest: compound 1; then compounds 3 and 2 (each within the scatter of the next).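

In this assay putting the group of 11 heavy atoms in place of the group of 10 heavy atoms, on a saturated chain carbon, five bonds along the chain from an amine nitrogen in a ring, gives a 1.6-fold lower number from compound 2 to compound 3 (0.19 log units; within the scatter) and so amounts to no real difference. Among the compounds shown here, this is the first direct reading of this position: the two groups have the same rings and the same hydrogen-bond counts, and this small change in size leaves inhibition indistinguishable from repeat-measurement noise. No supporting measurement is available to explain this result.

Still open, going by these compounds, is whether a longer chain at this place, or on the other side of the ring amine, would shift the number beyond the scatter. Compound 1 differs from compound 3 in more than one place, so its lower number cannot be traced to any single change.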